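The source may hold more compounds than are shown below. What is called first, only, known or untested is meant among the compounds shown, and "the series" means these compounds.

In a functional assay on cells (Tumor Cell line, Homo sapiens) for inhibition (on this read-out lower numbers stand for stronger inhibition of growth and higher numbers for weaker inhibition of growth), compound 1 `Cc1ccnc2nc(-c3cccc(Cl)c3)cc(O)c12` gives 25700 nM. Compound 2 `Cc1cc(C)c2c(O)cc(-c3cccc(Cl)c3)nc2n1` gives 26300 nM, level with compound 1 within the scatter, while compound 3 `Cc1cnc2[nH]c(-c3cccc(F)c3)cc(=O)c2c1` gives 5130 nM, a lower number than both. Compound 4 `Oc1cc(-c2cccc(Cl)c2)nc2ncccc12` is compound 1 with hydrogen in place of methyl on an aromatic carbon, opposite the ring nitrogen: hydrogen in place of methyl on an aromatic carbon. For the measured compounds named here, only one measured step bears on this, a methyl in place of hydrogen at a different aromatic carbon, a 1.0-fold higher number from compound 1 to compound 2 (0.01 log units; within the scatter). Going by the values given here, no measured step tests this methyl directly, so the expectation in this assay is only tentative, and no change beyond the scatter is expected. The estimated step is a 1.0-fold lower number from compound 1 to compound 4 (0.01 log units; within the scatter). For compound 4 the expected value is 25000 nM, with an estimated range from 11000 nM to 55000 nM.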

Compound 4, concentration for total growth inhibition: 24000 nM
For compound 4 the middle estimate is 1.0-fold (0.02 log units) above the measured one, within the range that was stated.
By their numbers in this assay, from the lowest: compound 3; then compounds 4, 1 and 2 (each within the scatter of the next).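

The methyl on this aromatic carbon, opposite the ring nitrogen, is now tested directly: in this assay its replacement by hydrogen gives a 1.1-fold lower number from compound 1 to compound 4 (0.03 log units; within the scatter) and leaves the number level. Alongside a 1.0-fold higher number from compound 1 to compound 2 (0.01 log units; within the scatter) at the other aromatic carbon, neither methyl step goes beyond the scatter. No evidence here bears on why this position tolerates the change.

The compounds shown leave open whether an amine, a carboxylic acid or a longer chain at this carbon would shift the number in this assay beyond the scatter.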